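Swapping the amide substituent on the cyclopropane carboxamide

A few compounds are considered here, and "the series" means these few. Any claim that something is new, unique, unknown or untested is made for them only; others in the source may bear on it.

Three compounds with a shared trimethoxyphenyl-bearing core have been examined in a functional assay on A549 cells (Homo sapiens) for cytotoxicity, read by MTT assay, with a stated time of 48 h; on this read-out higher numbers stand for weaker inhibition and lower numbers for stronger inhibition. Compound 1 `COc1cc([C@H]2C[C@]2(CO)C(=O)Nc2ccccc2Cl)cc(OC)c1OC` gives 36700 nM. Compound 2 `COc1cc([C@H]2C[C@@]2(CO)C(=O)NCc2ccc(C)cc2)cc(OC)c1OC` gives 63800 nM in this assay; of the two numbers it is the higher one, but compound 1 sits within the usual scatter of it, so the two cannot be told apart. For compound 3 `CCOC(=O)[C@@]1(C(=O)NCc2ccc(C)cc2)C[C@@H]1c1cc(OC)c(OC)c(OC)c1` this assay reports only a limit, > 100000 nM; that is the point at which (the limit of > 100000 nM in this assay, at which 1 of the 3 values shown sits).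

For the measured compounds named here, the one measured step, an at least 1.5-fold higher number from compound 2 to compound 3 (0.19 log units; that floor lies within the scatter), concerns ethoxycarbonyl in place of hydroxymethyl on a saturated ring carbon and therefore does not bear on the change now at hand.

Compound 4 `COc1cc([C@H]2C[C@@]2(CO)C(=O)Nc2ccccc2Cl)cc(OC)c1OC` differs from compound 2 by 2-chlorophenyl in place of 4-methylbenzyl on an amide-type nitrogen. Going by the values given here, no measured step speaks to this exchange, and the only other number, that of compound 1, lies within the scatter of compound 2. The expectation is therefore a step of a 1.6-fold lower number from compound 2 to compound 4 (0.20 log units; within the scatter), that is, nothing beyond the scatter. On that basis compound 4 is estimated at 40000 nM in this assay, with a range from 15000 nM to 100000 nM.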

Compound 4, half-maximal inhibitory concentration: > 100000 nM
Compound 4 gave a limit, no number (the forecaster's own chance of this, stated with the estimate: 15%); at least 2.5-fold (0.39 log units) between middle value and limit.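

In this assay compound 4 gives only a limit, so the exchange of 4-methylbenzyl for 2-chlorophenyl on the amide-type nitrogen can be read only as an at least 1.5-fold higher number from compound 2 to compound 4 (0.19 log units; that floor lies within the scatter), which fixes no size for this change and places compound 4 among the compounds at that limit: the limit of > 100000 nM in this assay, at which 2 of the 4 values shown sit.

What the earlier compounds did not show comes from the pair that keeps 2-chlorophenyl on the nitrogen and alters only the stereocentre, with an at least 2.7-fold higher number from compound 1 to compound 4 (0.43 log units; beyond the scatter), the only step shown so far that is printed as beyond the scatter. The gap can be assigned to the configuration at the saturated ring carbon, drawn S in compound 1 and R in compound 4, because nothing else separates the two: the fact that compounds 1 and 4 differ only in the configuration as drawn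

The compounds shown leave open whether the S configuration would also give a lower number with 4-methylbenzyl on the nitrogen, as no counterpart of compound 2 with that configuration appears among them. They also do not tell what an amine or a carboxylic acid in place of the hydroxymethyl on the saturated ring carbon would do under either configuration.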